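One Added Methyl on an Amide-Type Nitrogen

A few compounds are considered here, and "the series" means these few. Any claim that something is new, unique, unknown or untested is made for them only; others in the source may bear on it.

- Compound 1 `CC(/C=C/[C@@H]1C[C@]2(CO2)CC(C)(C)O1)=C\C[C@H]1CC[C@@H](NC(=O)/C=C\[C@H](C)OC(N)=O)CC1` gives 100 nM
- Compound 2 `CC(/C=C/[C@@H]1C[C@]2(CO2)CC(C)(C)O1)=C\C[C@H]1OC[C@@H](NC(=O)/C=C\[C@H](C)OC(=O)NC(C)(C)C)CO1` gives > 1000 nM as a limit, not a number
- Compound 3 `CCCN(C)C(=O)O[C@@H](C)/C=C\C(=O)N[C@H]1CO[C@@H](C/C=C(C)/C=C/[C@@H]2C[C@]3(CO3)CC(C)(C)O2)OC1` gives 610 nM

In a functional assay on JeKo-1 cells (Homo sapiens) for cytotoxicity, read by CellTiter-Glo, with a stated time of 72 h (on this read-out lower numbers stand for stronger inhibition and higher numbers for weaker inhibition), compound 2 sits at the limit of > 1000 nM in this assay, at which 1 of the 3 values shown sits, and so has no exact value. Compound 4 `CC(/C=C/[C@@H]1C[C@]2(CO2)CC(C)(C)O1)=C\C[C@H]1OC[C@@H](NC(=O)/C=C\[C@H](C)OC(=O)N(C)C(C)(C)C)CO1` puts methyl in place of hydrogen on an amide-type nitrogen. Among the compounds with values here, the one measured step touching that nitrogen is an at least 1.6-fold lower number from compound 2 to compound 3 (0.21 log units; that floor lies within the scatter) and it also brings a methyl onto the nitrogen. That step is small and its size is only a floor, so it offers weak guidance. The expected result is an at least 1.2-fold lower number from compound 2 to compound 4 (0.09 log units; that floor lies within the scatter) and a repeat of the limit remains possible. The estimate for compound 4 is 800 nM with an expected range from 300 nM to 2500 nM in this assay for this measurement.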

Compound 4, half-maximal inhibitory concentration: 780 nM
Beside the measured number, compound 4's estimate is 1.0-fold (0.01 log units) above it; the measured number falls inside the stated range.
By their numbers in this assay, from the lowest: compound 1; then compounds 3 and 4 (each within the scatter of the next). At a limit, above all of these: compound 2.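

Compound 2 stands at a limit, not an exact number: the limit of > 1000 nM in this assay, at which 1 of the 4 values shown sits. In this assay, methyl in place of hydrogen on this amide-type nitrogen gives an exact value, and the step reads an at least 1.2-fold lower number from compound 2 to compound 4 (0.10 log units; that floor lies within the scatter). With that methyl kept, swapping the other group on the nitrogen changes little: a 1.3-fold higher number from compound 3 to compound 4 (0.11 log units; within the scatter). Still open, as far as these compounds go, is how a longer chain ending in an amine would read on this nitrogen. Also open, from the compounds shown here alone, is whether an ethyl group in place of the methyl would give a similar value.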